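Compound 4: ethoxy in place of trifluoromethyl

The source may report more compounds than this note shows. Statements on the series, on what has been measured and on what is new or still open speak of the compounds shown alone.

In a functional assay on A549 cells (Homo sapiens) for antiproliferative activity, read by MTT assay, with a stated time of 48 h (on this read-out higher numbers stand for weaker inhibition and lower numbers for stronger inhibition), compound 1 `CCCCCCCCCCCCOc1ccc(C(=O)/C=C/c2c(/C=C/c3ccc(OC)cc3)cc(OC)cc2OC)cc1` gives 7.9 ug/mL, compound 2 `CCCC(C)Oc1ccc(C(=O)/C=C/c2c(/C=C/c3ccc(OC)cc3)cc(OC)cc2OC)cc1` gives 9.4 ug/mL and compound 3 `COc1ccc(/C=C/c2cc(OC)cc(OC)c2/C=C/C(=O)c2ccc(C(F)(F)F)cc2)cc1` gives 7.8 ug/mL. Compound 3 therefore stands level with the other two, as all three values lie within the scatter of one another.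

The next structure is compound 4 `CCOc1ccc(C(=O)/C=C/c2c(/C=C/c3ccc(OC)cc3)cc(OC)cc2OC)cc1`, with ethoxy in place of trifluoromethyl on an aromatic carbon, para to a large group: ethoxy in place of trifluoromethyl on an aromatic carbon.

For the measured compounds named here, two measured steps bear on this change. Trifluoromethyl in place of 1-methylbutoxy gave a 1.2-fold lower number from compound 2 to compound 3 (0.08 log units; within the scatter), which is the closest precedent. 1-Methylbutyl in place of dodecyl on the oxygen gave a 1.2-fold higher number from compound 1 to compound 2 (0.08 log units; within the scatter), so the two alkyl groups measured there show no separation. Ethoxy itself has not yet been measured in this series, so this remains an extrapolation from three compounds.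

No step beyond the scatter is expected, and the estimated change is a 1.1-fold higher number from compound 3 to compound 4 (0.04 log units; within the scatter). Compound 4 is expected at 8.5 ug/mL, with an estimated range of 4.5 ug/mL to 16 ug/mL.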

Compound 4, half-maximal inhibitory concentration: 7.5 ug/mL
Compound 4: middle estimate off by 1.1-fold (0.05 log units), on the high side; low and high end bracket the measured number.
By their numbers in this assay, from the lowest: compounds 4, 3, 1 and 2 (each within the scatter of the next).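

In this assay, ethoxy in place of trifluoromethyl on this aromatic carbon, para to a large group, gives a 1.0-fold lower number from compound 3 to compound 4 (0.02 log units; within the scatter) and so adds a direct comparison of an alkoxy group with trifluoromethyl at this position. The short ethoxy group also stands level with the longer groups on the same oxygen, giving a 1.3-fold lower number from compound 2 to compound 4 (0.10 log units; within the scatter) and a 1.1-fold lower number from compound 1 to compound 4 (0.02 log units; within the scatter), so all four compounds shown remain within the scatter, with no compound going against this. No measured evidence is available to explain this lack of separation.

On these data alone, whether an amine or a carboxylic acid at this position would move the number beyond the scatter stays open. Also open, as far as these compounds go, is whether replacing a methoxy group elsewhere on the shared core with a longer chain would do so.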